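Bromo in Place of Methoxy: Expected Cytotoxicity Shift

A few compounds are considered here, and "the series" means these few. Any claim that something is new, unique, unknown or untested is made for them only; others in the source may bear on it.

Compound 1 `COc1ccc(/C=C2\SC(=O)N(Cc3ccc(C(=O)O)cc3)C2=O)cc1` was tested in a functional assay on MCF7 cells (Homo sapiens) for cytotoxicity, read by MTT assay, with a stated time of 24 h (on this read-out higher numbers stand for weaker inhibition and lower numbers for stronger inhibition), where compound 1 gives 48000 nM. For the measured compounds named here, its only measured neighbour is compound 2 `Cc1ccc(/C=C2\SC(=O)N(Cc3ccc(C(=O)O)cc3)C2=O)cc1`, which in this assay gives 100000 nM; the step of a 2.1-fold higher number from compound 1 to compound 2 (0.32 log units; beyond the scatter) comes from methyl in place of methoxy on an aromatic carbon. On the numbers available, compound 1 stands lowest of the two. Compound 3 `O=C(O)c1ccc(CN2C(=O)S/C(=C\c3ccc(Br)cc3)C2=O)cc1` differs from compound 1 by bromo in place of methoxy on an aromatic carbon. Going by the values given here, no measured step involves bromo; the one step that bears on the change, a 2.1-fold higher number from compound 1 to compound 2 (0.32 log units; beyond the scatter), shows that replacing methoxy with another group on an aromatic carbon gave a modestly higher number. A modest step in the same direction, or none beyond the scatter, is therefore expected in this assay for compound 3. The estimate for compound 3 is 70000 nM, between 30000 nM and 160000 nM, an expected step of a 1.5-fold higher number from compound 1 to compound 3 (0.16 log units; within the scatter).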

Compound 3, half-maximal inhibitory concentration: 48000 nM
For compound 3 the middle estimate is 1.5-fold (0.16 log units) above the measured one; the measured number falls inside the stated range.
By their numbers in this assay, from the lowest: compounds 1 and 3 (each within the scatter of the next); then compound 2.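

In this assay, bromo in place of methoxy gives no change at the digits printed from compound 1 to compound 3 (within the scatter), so at this place, on an aromatic carbon para to a large group, a replacement for methoxy need not shift the number, as the step to compound 2 alone might have suggested. Bromo in place of methyl gives a 2.1-fold lower number from compound 2 to compound 3 (0.32 log units; beyond the scatter), which leaves methyl as the one group of the three that stands apart from the others, on a modest step. No measurement at hand accounts for why bromo and methoxy read alike here while methyl does not.

Going by these compounds, whether an amine, a nitrile or a plain hydrogen at this place would read with compounds 1 and 3 or with compound 2 stays open. All three compounds also keep the carboxylic acid and the shared core, so the effect of a change elsewhere is open too.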